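The source may report more compounds than this note shows. Statements on the series, on what has been measured and on what is new or still open speak of the compounds shown alone.

Compound 2 `Cc1cc(C(=O)Nc2cccc(I)c2)nn1-c1cccc(C(F)(F)F)c1` gives 670 nM in an assay on HEK293 cells for binding affinity to Neuropeptide Y receptor type 5 (Homo sapiens), read by radioligand binding (on this read-out lower numbers stand for stronger inhibition and higher numbers for weaker inhibition), the higher of the two numbers in hand, though the gap to compound 1 `Cc1cc(C(=O)Nc2cccc(Br)c2)nn1-c1cccc(C(F)(F)F)c1`, which gives 359 nM, lies within the scatter: the step of a 1.9-fold higher number from compound 1 to compound 2 (0.27 log units; within the scatter) is small. Compound 3 `Cc1cc(C(=O)Nc2cccc(OC(F)(F)F)c2)nn1-c1cccc(C(F)(F)F)c1` differs from compound 2 by trifluoromethoxy in place of iodo on an aromatic carbon. Going by the values given here, only that one step, a swap of one halogen for another, bears on this change, and it was modest, so no firm direction follows. Compound 3 is expected to give 500 nM in this assay, spanning 150 nM to 1600 nM, an estimated step of a 1.3-fold lower number from compound 2 to compound 3 (0.13 log units; within the scatter) near the scatter.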

Compound 3, half-maximal inhibitory concentration: 431 nM
Compound 3: middle estimate off by 1.2-fold (0.06 log units), on the high side; the range from low to high includes it.
By their numbers in this assay, from the lowest: compounds 1, 3 and 2 (each within the scatter of the next).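

Read in this assay trifluoromethoxy on this aromatic carbon stands level with both halogens (a 1.6-fold lower number from compound 2 to compound 3 (0.19 log units; within the scatter)) and (a 1.2-fold higher number from compound 1 to compound 3 (0.08 log units; within the scatter)). Five heavy atoms with one hydrogen-bond acceptor thus replace a single halogen atom with no step beyond the scatter in these three compounds. No evidence in hand accounts for this result. The compounds shown leave open whether an amine, a carboxylic acid or a nitrile on this carbon would shift the number beyond the scatter. They also leave open whether a hydrogen there would do so.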